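The compounds below may be only part of what the source reports. "The series", "measured", "known", "first", "only" and "open" are said of these compounds alone.

Two compounds of the series have a number in a functional assay on the whole organism for antagonist activity, with Rattus norvegicus as the target; on this read-out lower numbers stand for an effect already at smaller amounts and higher numbers for an effect only at larger amounts of compound. Compound 1 `C1=C(CCN2CCN(c3cccc4c3OCCO4)CC2)c2ccccc2CCC1` gives 5.02 mg/kg in this assay. Compound 2 `Fc1cccc2c1CC2CN1CCN(c2cccc3c2OCCO3)CC1` gives 2.51 mg/kg in this assay. Compound 2 holds the lowest of the two numbers; its nearest neighbour is compound 1, and the gap between the two lies within the scatter, so no order between them can be read from these values. For the measured compounds named here, no two measured compounds differ in a single place, so no measured step is available to anchor an expectation.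

Compound 3 `c1ccc2c(c1)CC2CN1CCN(c2cccc3c2OCCO3)CC1` has not yet been measured in this assay. It differs from compound 2 in one place: hydrogen in place of fluoro on an aromatic carbon. Nothing measured in the series bears directly on this change, and what the fluoro contributes to the number of compound 2 is not known. The step is therefore expected to be small, a 1.3-fold higher number from compound 2 to compound 3 (0.11 log units; within the scatter), with no change beyond the scatter in either direction. Compound 3 is expected to give about 3.2 mg/kg in this assay, within a range from 1.2 mg/kg to 8.5 mg/kg.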

Compound 3, dose for 50% inhibition: 0.67 mg/kg
For compound 3 the middle estimate is 4.8-fold (0.68 log units) above the measured one; measured number below the stated range.
By their numbers in this assay, from the lowest: compound 3; then compounds 2 and 1 (each within the scatter of the next).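

In this assay the series now has its first step beyond the scatter: a 3.7-fold lower number from compound 2 to compound 3 (0.57 log units; beyond the scatter) accompanies hydrogen in place of fluoro on an aromatic carbon, ortho to a fused ring and meta to a fused ring. This position therefore matters for the read-out, since exchanging one fluorine atom, with no ring, no net charge and no hydrogen-bond donors or acceptors involved, is enough to shift the number, and the compound with hydrogen acts at the smaller dose. The available data give no measured property that would account for this shift, so the step stands as an observation only.

On these data alone, whether methyl, chloro or methoxy on the same aromatic carbon would give a number closer to that of the hydrogen compound or the fluoro compound remains open, as does the outcome of moving the fluoro to another carbon of the same ring. Compound 1 differs from compound 2 and compound 3 in more than one place, so the series does not yet show whether this step would hold on the core of compound 1.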